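The source may hold more compounds than are shown below. What is called first, only, known or untested is meant among the compounds shown, and "the series" means these compounds.

Going by the values given here, in a functional assay on ileum (Cavia porcellus) for antagonist activity (a lower number here means a stronger inhibitor, a higher number a weaker inhibitor), compound 2 `CCCc1ccccc1OCC(O)COc1ccc2c(O)c([N+](=O)[O-])c(=O)oc2c1` stands at 110 nM and holds the lower of the two measured numbers, with compound 1 `CCc1ccccc1OCC(O)COc1ccc2c(O)c([N+](=O)[O-])c(=O)oc2c1` at 2700 nM as its only neighbour. Compound 3 `CCCc1cc(C(C)=O)ccc1OCC(O)COc1ccc2c(O)c([N+](=O)[O-])c(=O)oc2c1` keeps the propyl group of compound 2 and carries one change, (acetyl in place of hydrogen on an aromatic carbon), which is acetyl in place of hydrogen on an aromatic carbon, para to a large group. Among the compounds with values here, only one measured step exists, a 25-fold lower number from compound 1 to compound 2 (1.39 log units; beyond the scatter), and it lies on the saturated chain, not at this place. It bears on the new change only loosely, showing that one small edit on this side of the molecule can move the number far. Within the data shown here, no measured compound carries a group at this place, so either direction stays open. A moderate move to a lower number is expected, a 2.8-fold lower number from compound 2 to compound 3 (0.44 log units; beyond the scatter), smaller than the measured step. For compound 3 the estimate is 40 nM, with 8 nM to 200 nM as the expected range.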

Compound 3, half-maximal inhibitory concentration: 700 nM
Estimate against measurement, compound 3: 18-fold (1.24 log units) below; measured number above the stated range.
By their numbers in this assay, from the lowest: compound 2; then compound 3; then compound 1.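

In this assay, the first group measured at this place, acetyl in place of hydrogen on an aromatic carbon, para to a large group, gives a 6.4-fold higher number from compound 2 to compound 3 (0.80 log units; beyond the scatter), so the direction for this change is now known on the propyl background. That move is smaller than the one on the saturated chain, a 25-fold lower number from compound 1 to compound 2 (1.39 log units; beyond the scatter), and compound 3 keeps the propyl group, so the two steps sit at different places on the same side of the molecule. Nothing at hand gives a reason for the rise in the number.

A single group cannot show whether the rise belongs to acetyl itself or to any group at this place; a methyl, an amine or a carboxylic acid here would separate these readings. From the compounds shown here alone, whether acetyl moves the number the same way on the ethyl background of compound 1 also stays open.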